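Removing the bromo substituent from the phenyl of compound 1

A few compounds are considered here, and "the series" means these few. Any claim that something is new, unique, unknown or untested is made for them only; others in the source may bear on it.

Compound 1 `Brc1ccc(-c2nc3ccccn3c2NC2CCCCC2)cc1` is a cyclohexylamino-substituted bicyclic compound bearing a 4-bromophenyl group. In an assay on membranes from brain for displacement of a labelled ligand from adenosine receptor A1 (Rattus norvegicus) (on this read-out higher numbers stand for weaker inhibition and lower numbers for stronger inhibition), compound 1 gives 3900 nM. Its single measured companion, compound 2 `COc1ccc(-c2nc3ccccn3c2NC2CCCCC2)cc1`, carries a methoxy group in place of the bromo and in this assay compound 2 gives 7610 nM. The step of a 2.0-fold higher number from compound 1 to compound 2 (0.29 log units; within the scatter) stays within the scatter. On the numbers shown compound 1 has the lowest value of the two, with compound 2 nearest and not separated from it beyond the scatter.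

Compound 3 `c1ccc(-c2nc3ccccn3c2NC2CCCCC2)cc1` differs from compound 1 by hydrogen in place of bromo on an aromatic carbon. Within the data shown here, the only measured step that bears on this position is the exchange of bromo for methoxy, from compound 1 to compound 2, which produced no change beyond the scatter. Replacing bromo by hydrogen at the same place is therefore expected to give a step of the kind a 1.3-fold higher number from compound 1 to compound 3 (0.11 log units; within the scatter), without a clear direction. For compound 3 the estimate in this assay is 5000 nM, with a range from 1800 nM to 14000 nM.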

Compound 3, inhibition constant: > 100000 nM
Compound 3 ended at the assay's limit (the forecaster's own chance of this, stated with the estimate: 10%); at least 20-fold (1.30 log units) between middle value and limit.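

Among these compounds, the earlier exchange of bromo for methoxy, a 2.0-fold higher number from compound 1 to compound 2 (0.29 log units; within the scatter), showed only that these two groups could not be told apart at this place, para to a large group. The step to hydrogen shows that a substituent there matters in this assay: the change gives an at least 25-fold higher number from compound 1 to compound 3 (1.40 log units; beyond the scatter), and the comparison from the methoxy compound gives an at least 13-fold higher number from compound 2 to compound 3 (1.11 log units; beyond the scatter), so both substituted compounds read within the range of the assay while the unsubstituted phenyl of compound 3 does not. The value of compound 3 is a limit and not a number: the limit of > 100000 nM in this assay, at which 1 of the 3 values shown sits.

The compounds shown leave open whether the size of the substituent, its kind or simply its presence is what counts, and whether a chloro or fluoro atom, an amine, a carboxylic acid or a longer chain at this place would read like bromo and methoxy or like hydrogen. From the compounds shown here alone, how far compound 3 lies past its limit also stays unknown, so the full size of both steps to it cannot be given.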